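Swapping the methylsulfanyl group for an oxidised counterpart

The source may report more compounds than this note shows. Statements on the series, on what has been measured and on what is new or still open speak of the compounds shown alone.

Compound 1: `CSc1ccc(-c2nc3c(Sc4ccccc4)ncnc3n2C)cc1`, 0%
Compound 2: `CSc1ccc(-c2nc3c(Sc4ccc(F)cc4)ncnc3n2C)cc1`, 0%

Both compounds were tested in an assay on isolated protein for inhibition of Rho-associated protein kinase 1 (Homo sapiens), tested at 30 uM; a lower number here means less inhibition, a higher number more inhibition at the concentration tested (going by the name of the read-out). Compound 1 gives 0%, and compound 2 gives 0%. For the measured compounds named here, the one step that was measured, no change at the digits printed from compound 1 to compound 2 (within the scatter), came with a fluoro in place of hydrogen on an aromatic carbon. On these numbers compound 2 stands level with compound 1 at the digits shown, and both sit at the bottom of the read-out.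

Compound 3, `Cn1c(-c2ccc([S+](C)[O-])cc2)nc2c(Sc3ccc(F)cc3)ncnc21`, differs from compound 2 only at one spot: a group of 3 heavy atoms (1 carbon, 1 oxygen, 1 sulfur; no ring) in place of a group of 2 heavy atoms (1 carbon, 1 sulfur; no ring), on an aromatic carbon. Going by the values given here, no measured step touches the methylsulfanyl group itself, so nothing here speaks directly to this change. Among the compounds with values here, the only step available, from compound 1 to compound 2, was flat, and both measured compounds show no inhibition at all. A step of about a number 2 percentage points higher from compound 2 to compound 3 (within the scatter) is therefore expected, that is, none beyond the scatter. Compound 3 is estimated to give 2% in this assay, within the range 0% to 15%.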

Compound 3, a percentage reported as inhibition, at one concentration (the size of the read-out at that concentration, not a potency): 0%
Beside the measured number, compound 3's estimate is 2 percentage points above it; the range from low to high includes it.
By their numbers in this assay, from the lowest: compounds 1, 2 and 3 (each within the scatter of the next).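

In this assay, for the compounds shown here, replacing methylsulfanyl with the group that carries one added oxygen on its sulfur gives no change at the digits printed from compound 2 to compound 3 (within the scatter), the first measured change at this position, on an aromatic carbon para to a large group. The earlier step placed fluoro elsewhere in the molecule, so this result extends the flat picture to a second site: compound 3 gives 0% in this same test, and the added oxygen does not lift it off the bottom of the read-out at the single concentration tested. Nothing available explains this flat result.

With all of these compounds at the bottom of the read-out, any further loss of inhibition from this change could not be seen, so the result shows only that this swap does not bring inhibition into view. On these data alone, whether methylsulfonyl, an amine or a carboxylic acid at this position would give any measurable inhibition on the same core remains open.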